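Acyl substitution on the ring nitrogen of the shared core

The source may report more compounds than this note shows. Statements on the series, on what has been measured and on what is new or still open speak of the compounds shown alone.

Compound 3 `O=C(Nc1ccccc1C(F)(F)F)C1CCc2ccccc2N1` gives the highest number of the two plain values in a functional assay on NCI-H23 cells (Homo sapiens) for cytotoxicity, read by sulforhodamine B assay, with a stated time of 72 h (on this read-out lower numbers stand for stronger inhibition of growth and higher numbers for weaker inhibition of growth), at 56800 nM; compound 1 `O=C(Nc1ccc(C(F)(F)F)cc1)C1CCc2ccccc2N1` sits at 25800 nM. Compound 2 `CCCC(=O)N1c2ccccc2CCC1C(=O)Nc1ccccc1C(F)(F)F` reaches only a limit, > 70000 nM. Within the data shown here, the one measured step that bears on the change at hand is an at least 1.2-fold lower number from compound 2 to compound 3 (0.09 log units; that floor lies within the scatter), whose size is capped by the limit of > 70000 nM in this assay, at which 1 of the 3 values shown sits. Compound 4 `O=C(Nc1ccccc1C(F)(F)F)C1CCc2ccccc2N1C(=O)c1cccc(Cl)c1` carries (3-chlorophenyl)carbonyl in place of hydrogen on a nitrogen on an aromatic ring in a ring. Among the measured compounds shown here, with the only comparable change going, if anywhere, towards weaker inhibition, the step of a 1.1-fold higher number from compound 3 to compound 4 (0.06 log units; within the scatter) from compound 3 to compound 4 is expected to run the same way, with a real chance of another limit. Compound 4 is therefore estimated at 65000 nM, within 30000 nM to 150000 nM.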

Compound 4, concentration for 50% growth inhibition: 292 nM
Compound 4: the middle estimate sits 220-fold (2.35 log units) above what was measured, and the stated range ends above it.
By their numbers in this assay, from the lowest: compound 4; then compound 1; then compound 3. At a limit, above all of these: compound 2.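

In this assay this nitrogen tolerates substitution and can give a large gain: (3-chlorophenyl)carbonyl in place of hydrogen gives a 190-fold lower number from compound 3 to compound 4 (2.29 log units; beyond the scatter). Acylation alone does not account for the gain, as what the carbonyl carries matters: 3-chlorophenyl in place of propyl on the carbonyl carbon gives an at least 230-fold lower number from compound 2 to compound 4 (2.37 log units; beyond the scatter). Compound 2 stands at a limit, so that step is only a floor: the limit of > 70000 nM in this assay, at which 1 of the 4 values shown sits.

Still open, from the compounds shown here alone, is whether the gain needs the chlorine or only the aromatic ring, which a plain phenylcarbonyl group would separate. Also open, going by these compounds, is whether a methoxy or an amine on that ring would serve equally.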